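The source may report more compounds than this note shows. Statements on the series, on what has been measured and on what is new or still open speak of the compounds shown alone.

Compound 3 `CN(C)c1ccc([C@H]2CC(c3cc4ccccc4oc3=O)=NN2c2ccccc2)cc1` sits second highest of the three numbers in a functional assay on the whole organism (strain albino) for inhibition, with Rattus norvegicus as the target, read by paw edema, with stated times of 1 h and 4 h, at a dose of 200 mg/kg by the oral route; a higher number here means more inhibition at the dose given (going by the name of the read-out), a lower number less inhibition: compound 3 gives 40.1%, compound 1 `O=c1oc2ccccc2cc1C1=NN(c2ccccc2)[C@@H](c2ccccc2)C1` gives 32.7%, and compound 2 `O=c1oc2ccccc2cc1C1=NN(c2ccccc2)[C@@H](c2ccc(Cl)cc2Cl)C1` gives 67.5%. The step of a number 7.4 percentage points higher from compound 1 to compound 3 (within the scatter) lies within the scatter, whereas a number 27.4 percentage points lower from compound 2 to compound 3 (beyond the scatter) and a number 34.8 percentage points higher from compound 1 to compound 2 (beyond the scatter) are beyond it. Compound 4 `O=c1oc2ccccc2cc1C1=NN(c2ccccc2)[C@@H](c2ccc(F)cc2)C1` differs from compound 3 by fluoro in place of dimethylamino on an aromatic carbon. Only the halogen-bearing compound 2 bears on a halogen entering here, and its rise from compound 1 was large; but compound 2 carries two chlorines where compound 4 carries one fluorine, so a smaller rise is expected. For compound 4 the estimated result is 46%, with a range from 32% to 62%, meaning an expected step of a number 5.9 percentage points higher from compound 3 to compound 4 (within the scatter) in this assay.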

Compound 4, a percentage reported as inhibition, in the whole organism at one dose (the size of the read-out at that dose, not a potency): 66.7%
The estimate for compound 4 lay 20.7 percentage points below the measured number, and the stated range ends below it.
By their numbers in this assay, from the lowest: compounds 1 and 3 (each within the scatter of the next); then compounds 4 and 2 (each within the scatter of the next).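

In this assay, fluoro on the aromatic carbon alone carries a large change: a number 34 percentage points higher from compound 1 to compound 4 (beyond the scatter), whereas dimethylamino there did not move the number beyond the scatter, and a number 26.6 percentage points higher from compound 3 to compound 4 (beyond the scatter). Two chlorines are not required to reach this level, for a number 0.8 percentage points lower from compound 2 to compound 4 (within the scatter). No evidence here accounts for these steps. From the compounds shown here alone, whether a chloro or a methoxy group at this same place would read like fluoro remains open, as does the result for a hydroxyl group.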